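The compounds below may be only part of what the source reports. "The series", "measured", "known", "first", "only" and "open" are said of these compounds alone.

Compound 1, `CCN(CC)C(=O)CN(c1cc2c(C)nsc2cc1Cl)S(=O)(=O)c1ccc(OC)c(OC)c1`: in a functional assay on CHO cells for inhibition of Orexin/Hypocretin receptor type 1 (Homo sapiens), read by FLIPR and calcium flux (on this read-out higher numbers stand for weaker inhibition and lower numbers for stronger inhibition), compound 1 gives 29 nM.
Compound 2, `CCN(CC)C(=O)CN(c1cc(C(C)C)ccc1Cl)S(=O)(=O)c1ccc(OC)c(OC)c1`: in this assay compound 2 gives 888 nM.
Compound 3, `CCN(CC)C(=O)CN(c1ccc(C)cc1)S(=O)(=O)c1ccc(OC)c(OC)c1`: in this assay compound 3 gives > 10000 nM, which is a limit of the assay and not a number.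

Compound 3 thus stands at the weak end of the three measured compounds, at the limit of > 10000 nM in this assay, at which 1 of the 3 values shown sits. The step to compound 4, `CCN(CC)C(=O)CN(c1cc(N(C)C)ccc1OC)S(=O)(=O)c1ccc(OC)c(OC)c1`, changes the group on the sulfonamide nitrogen: 5-(dimethylamino)-2-methoxyphenyl in place of 4-methylphenyl on a sulfonamide nitrogen. Among the compounds with values here, two measured steps bear on this. The step of an at least 340-fold higher number from compound 1 to compound 3 (2.53 log units; beyond the scatter) and the step of an at least 11-fold higher number from compound 2 to compound 3 (1.05 log units; beyond the scatter) both show that the 4-methylphenyl group on the sulfonamide nitrogen sits far above the larger, substituted aryl groups of compound 1 and compound 2. Compound 4 carries a substituted six-membered ring of similar size, so a large step toward lower numbers is expected from compound 3 to compound 4, though how far it goes is uncertain because compound 3 gives only > 10000 nM. The estimate for compound 4 is 1000 nM, between 150 nM and 8000 nM, meaning an expected step of an at least 10-fold lower number from compound 3 to compound 4 (1.00 log units; beyond the scatter).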

Compound 4, half-maximal inhibitory concentration: > 10000 nM
Compound 4: no number, only a limit (the forecaster's own chance of this, stated with the estimate: 20%); at least 10-fold (1.00 log units) between middle value and limit.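

Compound 4 sits at a limit of this assay, not at a number, and it is the second compound to do so: the limit of > 10000 nM in this assay, at which 2 of the 4 values shown sit. So a substituted six-membered carbon ring on the sulfonamide nitrogen is not enough by itself, as the 5-(dimethylamino)-2-methoxyphenyl group stays far from the groups of the two measured compounds, with an at least 11-fold higher number from compound 2 to compound 4 (1.05 log units; beyond the scatter) and an at least 340-fold higher number from compound 1 to compound 4 (2.53 log units; beyond the scatter). Compound 3 and compound 4 both stand at limits, so the step between them cannot be read, and the 5-(dimethylamino)-2-methoxyphenyl group cannot be ranked against 4-methylphenyl.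

The compounds shown leave open whether the methoxy or the dimethylamino part of the group accounts for the gap to compound 2. They also leave open how a 2-chloro-5-(dimethylamino)phenyl group, which keeps the chlorine of compound 2, would read on this nitrogen.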